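Replacing 4-fluorophenyl in compound 2

A few compounds are considered here, and "the series" means these few. Any claim that something is new, unique, unknown or untested is made for them only; others in the source may bear on it.

Values in an ADME assay on HEK293 cells (Homo sapiens) for cytotoxicity, with a stated time of 72 h (on this read-out higher numbers stand for an effect only at larger amounts of compound and lower numbers for an effect already at smaller amounts), are as follows:
Compound 1 `Cc1cc(NC(=O)Nc2ccc(F)c(F)c2)c2ccccc2n1` gives > 25000 nM (a limit)
Compound 2 `Cc1cc(NC(=O)Nc2ccc(F)cc2)c2ccccc2n1` gives > 25000 nM (a limit)
Compound 3 `Cc1cc(NC(=O)Nc2ccc(SC(F)(F)F)cc2)c2ccccc2n1` gives 13000 nM (a number)

As far as these compounds go, compound 2 has no number in this assay but only a limit: it sits at the limit of > 25000 nM in this assay, at which 2 of the 3 values shown sit, and the starting point of this account stays open on one side.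

Compound 4 `Cc1cc(NC(=O)Nc2ncccc2C)c2ccccc2n1` differs from compound 2 in one place: 3-methylpyridin-2-yl in place of 4-fluorophenyl on an amide-type nitrogen.

Among the measured compounds shown here, two measured steps touch that same group. One is a step that the two limits leave unreadable from compound 1 to compound 2 and gives nothing to go on. The other is an at least 1.9-fold lower number from compound 2 to compound 3 (0.28 log units; that floor lies within the scatter) and stays modest as far as it can be read. For the measured compounds named here, compound 3 at 13000 nM is the only compound with a number, and it offers no sign of a large move. Neither step swaps the whole group, and they bear on compound 4 only loosely.

The expectation is therefore a step that the limit leaves unreadable from compound 2 to compound 4 with no step beyond the scatter, and another report of a limit would be no surprise. For compound 4 the estimated value is 28000 nM with an expected range from 13000 nM to 60000 nM as a rough guide.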

Compound 4, half-maximal effective concentration: > 25000 nM
Compound 4: only a limit was reported; the forecaster's own chance of this, stated with the estimate: 70%; the middle value lies beyond the limit too.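

In this assay compound 4 gives > 25000 nM as a limit and not a number. Among the compounds shown here, compound 2 is also reported only as a limit, so no step between compound 2 and compound 4 can be read, and both stand at the same place: the limit of > 25000 nM in this assay, at which 3 of the 4 values shown sit. The compounds shown leave open whether 3-methylpyridin-2-yl in place of 4-fluorophenyl changes the value at all.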